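The compounds below may be only part of what the source reports. "The series", "measured", "known", "first", "only" and "open" are said of these compounds alone.

Measured so far:
Compound 1 `Cn1cc(S(=O)(=O)NC(=O)NC/C=C2\CCCc3cnn(Cc4ccc(Cl)cc4Cl)c32)cn1` gives 9 nM in an assay on isolated protein for displacement of a labelled ligand from prostaglandin E2 receptor EP3 subtype (Homo sapiens), read by scintillation counting, with a stated time of 2 h; on this read-out lower numbers stand for stronger inhibition and higher numbers for weaker inhibition.
Compound 2 `O=C(NC/C=C1\CCCc2cnn(-c3ccc(C(F)(F)F)cc3)c21)NS(=O)(=O)c1cc(Cl)c(Cl)s1` gives 0.4 nM in this assay.

Of these two numbers, compound 2 holds the lower one. Among the compounds with values here, its only neighbour, compound 1, sits at a number higher by a margin that lies beyond the usual scatter of such measurements. Compound 1 and compound 2 differ from each other in more than one place, so their two values show that gap and nothing about any single structural change.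

Compound 3 `CS(=O)(=O)c1ccc(-n2ncc3c2/C(=C/CNC(=O)NS(=O)(=O)c2cc(Cl)c(Cl)s2)CCC3)cc1` has not yet been measured. It differs from compound 2 in one place only: methylsulfonyl in place of trifluoromethyl on an aromatic carbon. Within the data shown here, no pair of measured compounds carries just this change, so the size of the step has no precedent within this set. The account expects at most a modest step, if any, toward a higher number, with a move that stays within the scatter being equally plausible. Compound 3 is estimated at 1 nM in this assay, in a range from 0.2 nM to 6 nM. That estimate means an expected step of a 2.5-fold higher number from compound 2 to compound 3 (0.40 log units; beyond the scatter), judged small.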

Compound 3, inhibition constant: 1 nM
Beside the measured number, compound 3's estimate shows no gap at the digits printed; the measured number falls inside the stated range.
By their numbers in this assay, from the lowest: compound 2; then compound 3; then compound 1.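

In this assay, within the data shown here, the exchange of trifluoromethyl for methylsulfonyl on an aromatic carbon, para to a large group, is the first single change that can be read in this set, and it amounts to a 2.5-fold higher number from compound 2 to compound 3 (0.40 log units; beyond the scatter) and is modest, though beyond the scatter. The position therefore tolerates this swap of one group of 4 heavy atoms for another, with 2 hydrogen-bond acceptors entering where trifluoromethyl carried 0, and compound 3 still gives 1 nM on this read-out. No measurement shown here accounts for the size of this step or ties it to any property of either group.

The compounds shown leave open how other groups at this same place would compare, such as a nitrile, a methoxy group, a carboxylic acid or an amine, or a bare hydrogen with no group there at all. They also leave open whether the same exchange would give a step of similar size on a compound that differs elsewhere, such as compound 1 with its own set of substituents.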